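Moving the Pyridine Nitrogen: Compound 3 to Compound 4

The compounds below may be only part of what the source reports. "The series", "measured", "known", "first", "only" and "open" are said of these compounds alone.

In an ADME assay on microsomes from liver (Rattus norvegicus) for metabolic stability, read by LC-MS, tested at 0.5 uM (a higher number here means that the compound lasts longer, a lower number that the compound disappears faster), compound 1 `Cc1nc(C)c([C@H](OC(C)(C)C)C(=O)O)c(N2CCC(C)(C)CC2)c1-c1ccc(OCCc2ccc(F)c(F)c2)cc1` gives 0.85 h. Compound 2 `Cc1nc(C)c([C@H](OC(C)(C)C)C(=O)O)c(N2CCC(C)(C)CC2)c1-c1ccc(OC2COCC2c2ccc(F)cc2)cc1` reaches only a limit of this assay, > 2 h. Compound 3 `Cc1nc(C)c([C@H](OC(C)(C)C)C(=O)O)c(N2CCC(C)(C)CC2)c1-c1ccc(OCCc2ccccn2)cc1` gives 1.02 h. The step here is a 1.2-fold higher number from compound 1 to compound 3 (0.08 log units; within the scatter), so the two sit within the scatter of each other. Compound 4 `Cc1nc(C)c([C@H](OC(C)(C)C)C(=O)O)c(N2CCC(C)(C)CC2)c1-c1ccc(OCCc2cccnc2)cc1` differs from compound 3 by pyridin-3-yl in place of pyridin-2-yl on a saturated chain carbon, two bonds along the chain from an oxygen on an aromatic ring. For the measured compounds named here, no measured step moves the ring nitrogen alone; the closest guide is a 1.2-fold higher number from compound 1 to compound 3 (0.08 log units; within the scatter), where replacing the ring at this place left the half-life within the scatter. A step within the scatter is therefore expected here too. Compound 4 is expected to give 1 h, with a range from 0.5 h to 2 h. The expected step is a 1.0-fold lower number from compound 3 to compound 4 (0.01 log units; within the scatter).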

Compound 4, half-life: 0.783 h
Beside the measured number, compound 4's estimate is 1.3-fold (0.11 log units) above it; measured number inside the range.
By their numbers in this assay, from the lowest: compounds 4, 1 and 3 (each within the scatter of the next). At a limit, above all of these: compound 2.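

In this assay, moving the ring nitrogen gives a 1.3-fold lower number from compound 3 to compound 4 (0.11 log units; within the scatter), and replacing the 3,4-difluorophenyl ring with pyridin-3-yl gives a 1.1-fold lower number from compound 1 to compound 4 (0.04 log units; within the scatter), so neither the nitrogen's place nor the choice among these three rings separates the half-lives at this position. A step beyond the scatter appears only when the whole group on the oxygen changes: an at least 2.5-fold lower number from compound 2 to compound 4 (0.40 log units; beyond the scatter). Compound 2 has only a limit, not a number: the limit of > 2 h in this assay, at which 1 of the 4 values shown sits.

As far as these compounds go, whether pyridin-4-yl would also stay within the scatter remains open. So does the effect of a longer chain between the oxygen and the pyridine ring.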